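A few compounds are considered here, and "the series" means these few. Any claim that something is new, unique, unknown or untested is made for them only; others in the source may bear on it.

Compound 1 `COc1ccc(NC(=O)c2ccc3cccc(O)c3n2)cc1` was tested in an ADME assay on THP-1 cells (Homo sapiens) for cytotoxicity, read by WST assay, with a stated time of 24 h; a lower number here means a stronger inhibitor, a higher number a weaker inhibitor. In this assay compound 1 gives > 30000 nM, which is a limit of the assay rather than a number. Compound 2 `O=C(Nc1ccccc1[N+](=O)[O-])c1ccc2cccc(O)c2n1` returns > 30000 nM in this assay, again a limit and not a number. Compound 1 thus stands at the edge of what this assay reports, and nothing separates it from compound 2 on the numbers shown, since both sit at the limit of > 30000 nM in this assay, at which 2 of the 2 values shown sit. Compound 3 `O=C(Nc1ccc([N+](=O)[O-])cc1)c1ccc2cccc(O)c2n1` has not yet been measured in this assay. It differs from compound 1 by a nitro in place of methoxy on an aromatic carbon, para to a large group (nitro in place of methoxy on an aromatic carbon). Among the compounds with values here, no step between measured compounds is available, and the two values at hand are both limits, so no direction beyond the scatter can be read from them. On this basis a step that the limit leaves unreadable from compound 1 to compound 3 is expected to be no change beyond the scatter. Compound 3 is therefore estimated to come out around 40000 nM, between 15000 nM and 120000 nM, most probably reported once more as a limit.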

Compound 3, half-maximal inhibitory concentration: > 30000 nM
Compound 3: a limit, no number (the forecaster's own chance of this, stated with the estimate: 85%); the middle value does not contradict the limit.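

No step can be read from compound 1 to compound 3 in this assay, since compound 3, like compound 1, returns only a limit of the assay and not a number: the limit of > 30000 nM in this assay, at which 3 of the 3 values shown sit. The compounds shown leave open whether nitro in place of methoxy on an aromatic carbon changes this read-out at all.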